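Dropping the 4-acetylphenyl: compound 2 to compound 3

The source may hold more compounds than are shown below. What is called first, only, known or untested is meant among the compounds shown, and "the series" means these compounds.

Measured so far:
compound 1 `COC1Cc2c(csc2-c2ccc([N+](=O)[O-])cc2)C2(CCN(Cc3ccccc3)CC2)O1`, 1 nM
compound 2 `COC1Cc2cc(-c3ccc(C(C)=O)cc3)sc2C2(CCN(Cc3ccccc3)CC2)O1`, 59 nM

In an assay on membranes from brain for displacement of a labelled ligand from Sigma non-opioid intracellular receptor 1 (Cavia porcellus), read by scintillation counting, with a stated time of 120 min (on this read-out higher numbers stand for weaker inhibition and lower numbers for stronger inhibition), compound 2 gives 59 nM, the highest of the two numbers; compound 1 gives 1 nM, and the gap between the two lies beyond the scatter. Compound 3 `COC1Cc2ccsc2C2(CCN(Cc3ccccc3)CC2)O1` differs from compound 2 by hydrogen in place of 4-acetylphenyl on an aromatic carbon. Among the compounds with values here, no pair of measured compounds covers this change, so the expectation rests on the two values alone. Compound 3 is expected to give 25 nM in this assay, with a range from 4 nM to 150 nM. The estimate corresponds to a step of a 2.4-fold lower number from compound 2 to compound 3 (0.37 log units; beyond the scatter) expected to stay close to the scatter.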

Compound 3, inhibition constant: 1.9 nM
Compound 3: the middle estimate sits 13-fold (1.12 log units) above what was measured; measured number outside the range, below it.
By their numbers in this assay, from the lowest: compounds 1 and 3 (each within the scatter of the next); then compound 2.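

Hydrogen in place of 4-acetylphenyl, on the aromatic carbon next to the ring sulfur, gives a 31-fold lower number from compound 2 to compound 3 (1.49 log units; beyond the scatter) in this assay. This position therefore needs no aryl group for a low number, and in this pair the 4-acetylphenyl carries a clear penalty rather than a gain.

Open, from the compounds shown here alone, is whether the penalty comes with any substituent at this carbon: a methyl, an amine or a plain phenyl would separate the ring from its acetyl. No measurement on hand accounts for the size of this step.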